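A few compounds are considered here, and "the series" means these few. Any claim that something is new, unique, unknown or untested is made for them only; others in the source may bear on it.

In a functional assay on THP-1 cells (Homo sapiens) for inhibition, read by sulforhodamine B assay, with a stated time of 48 h, tested at 50 uM (a higher number here means more inhibition of growth at the concentration tested, a lower number less inhibition of growth), compound 1 (`COc1cc(/C=C/C(=O)/C=C/c2ccccc2)ccc1OCc1cn(CCCCOc2cc(=O)oc3ccccc23)nn1`) gives 36% and stands lowest of the three numbers available. Compound 3 (`COc1ccc(/C=C/C(=O)/C=C/c2ccc(OCc3cn(CCOc4cc(=O)oc5ccccc45)nn3)c(OC)c2)cc1OC`) gives 90% and compound 2 (`COc1cc(/C=C/C(=O)/C=C/c2cc(OC)c(OC)c(OC)c2)ccc1OCc1cn(CCOc2cc(=O)oc3ccccc23)nn1`) gives 99% in the same test, both beyond the scatter from compound 1. For the measured compounds named here, no measured step that differs in one place links compound 1 to either of them, so these gaps show only where it stands.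

Compound 4 (`COc1cc(/C=C/C(=O)/C=C/c2cccs2)ccc1OCc1cn(CCCCOc2cc(=O)oc3ccccc23)nn1`) has not yet been measured. Its difference from compound 1 is this: thiophen-2-yl in place of phenyl on a double-bonded chain carbon bound to a double-bonded chain carbon. In short, thiophen-2-yl sits in place of phenyl on a double-bonded chain carbon bound to a double-bonded chain carbon.

Going by the values given here, no measured pair makes this exchange. The nearest guide is hydrogen in place of methoxy on an aromatic carbon, which gave a number 9 percentage points lower from compound 2 to compound 3 (within the scatter) and thus no change that can be told from the scatter. That is a different change, measured on compounds with much higher numbers, so it bears on compound 4 only loosely. The expectation is therefore a small move, with no firm direction: the estimated step is a number 4 percentage points higher from compound 1 to compound 4 (within the scatter) and should stay within the scatter. Compound 4 is estimated at 40% with an expected range from 20% to 65%.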

Compound 4, percent growth inhibition at one concentration: 44%
For compound 4 the middle estimate is 4 percentage points below the measured one; low and high end bracket the measured number.
By their numbers in this assay, from the lowest: compounds 1 and 4 (each within the scatter of the next); then compounds 3 and 2 (each within the scatter of the next).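

In this assay, for the compounds shown here, thiophen-2-yl in place of phenyl on a double-bonded chain carbon bound to a double-bonded chain carbon gives a number 8 percentage points higher from compound 1 to compound 4 (within the scatter), the first direct reading of any exchange at this position. The earlier step changed only a methoxy on an aromatic carbon, whereas this one replaces a whole six-membered aromatic ring of carbon only with a five-membered aromatic ring holding sulfur, and the read-out still shows no change that can be told from the scatter, so at this single test concentration the position accepts this ring exchange on the core of compound 1. Nothing available explains this result.

From the compounds shown here alone, two aromatic rings without further groups say little about how much this position can accept, so it remains open whether a pyridin-2-yl ring, or a phenyl ring carrying an amine or a carboxylic acid, would move the number beyond the scatter. Going by these compounds, it is also open whether the same thiophen-2-yl exchange would read alike on the core of compound 3, whose number lies far higher in this test.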